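Hydroxyl in the chain of a lipid lactone

The source may report more compounds than this note shows. Statements on the series, on what has been measured and on what is new or still open speak of the compounds shown alone.

Compound 1 `COCCCCCCCCCCCCCCC/C=C1\CC(CO)(COC(=O)C(C)(C)C)OC1=O` is one of three analogues sharing a lactone core with a long chain that carries a terminal oxygen function. In a functional assay on HL-60 cells (Homo sapiens) for antiproliferative activity (a higher number here means a weaker inhibitor of growth, a lower number a stronger inhibitor of growth), compound 1 gives 4.65 ug/mL, the highest of the two numbers reported; its geometric isomer compound 3 `COCCCCCCCCCCCCCCC/C=C1/CC(CO)(COC(=O)C(C)(C)C)OC1=O` gives 3.97 ug/mL, and the step of a 1.2-fold lower number from compound 1 to compound 3 (0.07 log units; within the scatter) is within the scatter. Compound 2 `CC(C)(C)C(=O)OCC1(CO)C/C(=C/CCCCCCCCCCCCCCC=O)C(=O)O1` gives only a limit in this assay, > 10 ug/mL. The step of an at least 2.5-fold lower number from compound 2 to compound 3 (0.40 log units; beyond the scatter) shows that the formyl-bearing chain is the weaker of the two, by at least a modest margin.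

Compound 4 `CCCCCCCCC(O)CCCCCC/C=C1\CC(CO)(COC(=O)C(C)(C)C)OC1=O` is the unmeasured analogue. It differs from compound 1 as follows: 1-hydroxynonyl in place of 9-methoxynonyl on a saturated chain carbon, six bonds along the chain from a double-bonded chain carbon. Among the compounds with values here, no measured step concerns a hydroxyl in the chain or the loss of the methoxy end, so the only guidance is indirect: changing the chain terminus in the step from compound 2 to compound 3 moved the number beyond the scatter, whereas the change of double-bond geometry did not. A change of modest size is expected in this assay, more likely toward a higher number than a lower one, and the step of a 1.3-fold higher number from compound 1 to compound 4 (0.11 log units; within the scatter) is the estimate. Compound 4 is therefore expected to give about 6 ug/mL, within a range of 2.5 ug/mL to 15 ug/mL.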

Compound 4, concentration for 50% growth inhibition: > 10 ug/mL
Compound 4: only a limit was reported; the forecaster's own chance of this, stated with the estimate: 20%; middle value at least 1.6-fold (0.22 log units) away from the limit.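

In this assay, 1-hydroxynonyl in place of 9-methoxynonyl, on a saturated chain carbon six bonds along the chain from a double-bonded chain carbon, gives an at least 2.1-fold higher number from compound 1 to compound 4 (0.33 log units; beyond the scatter). The earlier steps shown here showed a shift beyond the scatter only for the exchange of formyl and methoxymethyl at the chain end, in an at least 2.5-fold lower number from compound 2 to compound 3 (0.40 log units; beyond the scatter); this step shows that a second change in the chain can also raise the number beyond the scatter, whereas the change of double-bond geometry in a 1.2-fold lower number from compound 1 to compound 3 (0.07 log units; within the scatter) did not. Compound 4 gives a limit and not a number, so the printed step sets only a lower bound on the size of the change, because the comparison rests on this value: the limit of > 10 ug/mL in this assay, at which 2 of the 4 values shown sit.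

This single step introduces the hydroxyl and removes the methoxy end together, so the compounds shown do not tell which of the two goes with the higher number. A chain with an amine at the same carbon, or a 1-methoxynonyl chain, would be needed to tell whether the change depends on the hydroxyl itself or on the loss of the methoxy end.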